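The source may hold more compounds than are shown below. What is called first, only, known or untested is meant among the compounds shown, and "the series" means these compounds.

Three compounds share one core and differ only in the group on the aromatic nitrogen. Compound 1 `COc1ccc([N+](=O)[O-])cc1CSc1nc2cc(NC(=O)NC(C)(C)C)ccc2n1C1CC1` gives 860 nM in an assay on isolated protein for inhibition of Gonadotropin-releasing hormone receptor (Rattus norvegicus); on this read-out lower numbers stand for stronger inhibition and higher numbers for weaker inhibition. Compound 2 `CCCn1c(SCc2cc([N+](=O)[O-])ccc2OC)nc2cc(NC(=O)NC(C)(C)C)ccc21` gives 120 nM, and compound 3 `CCCCCn1c(SCc2cc([N+](=O)[O-])ccc2OC)nc2cc(NC(=O)NC(C)(C)C)ccc21` gives 880 nM. Compound 3 thus shows the highest number of the three, but the step of a 1.0-fold higher number from compound 1 to compound 3 (0.01 log units; within the scatter) places the two together, while the gap a 7.3-fold higher number from compound 2 to compound 3 (0.87 log units; beyond the scatter) separates it clearly from compound 2.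

Compound 4 `COc1ccc([N+](=O)[O-])cc1CSc1nc2cc(NC(=O)NC(C)(C)C)ccc2n1Cc1cccnc1` is not yet measured. It differs from compound 3 by pyridin-3-yl in place of butyl on a saturated chain carbon bound to an aromatic nitrogen. Among the compounds with values here, no measured step introduces an aromatic ring at this position, so the three known steps only frame the question. The step of a 7.2-fold lower number from compound 1 to compound 2 (0.86 log units; beyond the scatter) and the step of a 7.3-fold higher number from compound 2 to compound 3 (0.87 log units; beyond the scatter) show that changing the size of a saturated group on this nitrogen can move the number a good deal, while a 1.0-fold higher number from compound 1 to compound 3 (0.01 log units; within the scatter) shows that it can also leave it untouched. The direction for an aromatic heterocycle is therefore open.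

On balance compound 4 is expected to land somewhere between the measured extremes, with the step from compound 3 estimated at a 2.2-fold lower number from compound 3 to compound 4 (0.34 log units; beyond the scatter). The estimate for compound 4 in this assay is 400 nM, with a range from 80 nM to 2000 nM.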

Compound 4, half-maximal inhibitory concentration: 150 nM
Compound 4: middle estimate off by 2.7-fold (0.43 log units), on the high side; measured number inside the range.
By their numbers in this assay, from the lowest: compounds 2 and 4 (each within the scatter of the next); then compounds 1 and 3 (each within the scatter of the next).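

In this assay the pyridin-3-yl group replaces butyl on the saturated chain carbon bound to the aromatic nitrogen with a 5.9-fold lower number from compound 3 to compound 4 (0.77 log units; beyond the scatter) (beyond the scatter as printed), so this position accepts an aromatic ring and not only saturated groups. The step of a 1.3-fold higher number from compound 2 to compound 4 (0.10 log units; within the scatter) places the (pyridin-3-yl)methyl group level with propyl, while a 5.7-fold lower number from compound 1 to compound 4 (0.76 log units; beyond the scatter) sets it apart from cyclopropyl. Although pyridin-3-yl has more heavy atoms than the butyl it replaces, it gives the lower number, so the rise seen from propyl to pentyl does not hold for every larger group here, and nothing in the data at hand explains this.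

The compounds shown leave open whether a benzyl group, with carbon in place of the ring nitrogen, would match compound 4, and so whether that nitrogen counts at all. Also open, going by these compounds, is how pyridin-2-yl or pyridin-4-yl on the same carbon would compare, and whether a butyl chain on the aromatic nitrogen would stay with propyl or with pentyl.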